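The source may report more compounds than this note shows. Statements on the series, on what has been measured and on what is new or still open speak of the compounds shown alone.

Compounds measured in an ADME assay on Vero cells (Chlorocebus sabaeus) for cytotoxicity; a higher number here means that more compound is tolerated, a lower number that less compound is tolerated:
- compound 1, `Fc1ccc(-c2nn3c(NC4CCCC4)cccc3c2-c2cccnc2)cc1`: > 40000 nM
- compound 2, `Nc1nc(-c2c(-c3ccc(F)cc3)nn3c(NC4CCCC4)cccc23)cs1`: "not determined" (no result reported)
- compound 3, `Nc1n[nH]cc1-c1c(-c2ccc(F)cc2)nn2c(NC3CCCC3)cccc12`: 20000 nM

Compound 1 reaches only a limit of this assay, > 40000 nM, and not a number. Compound 2 has no result in this assay. Among the compounds with values here, compound 3 therefore holds the only number among the three, giving 20000 nM in this assay.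

Within the data shown here, one measured step touches the same position on the shared core: going from compound 1 to compound 3, the change is an at least 2.0-fold lower number from compound 1 to compound 3 (0.30 log units; that floor lies within the scatter). Because one of the three values sits at the limit of > 40000 nM in this assay, at which 1 of the 3 values shown sits, the size of that step cannot be pinned down.

Compound 4, `Fc1ccc(-c2nn3c(NC4CCCC4)cccc3c2-c2c[nH]c(NC3CCCC3)n2)cc1`, carries the change (2-(cyclopentylamino)-1H-imidazol-4-yl in place of 3-amino-1H-pyrazol-4-yl on an aromatic carbon). Among the measured compounds shown here, the step from compound 1 to compound 3 is the only measured guide, and it exchanged a different group at this position; it gives no step beyond the scatter to lean on. Compound 4 is therefore expected to show no change at the digits printed from compound 3 to compound 4 (within the scatter) in this assay, within the scatter. The estimate for compound 4 in this assay is 20000 nM, with a range from 7000 nM to 50000 nM.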

Compound 4, half-maximal cytotoxic concentration: 40000 nM
Compound 4: the middle estimate sits 2.0-fold (0.30 log units) below what was measured; measured number inside the range.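

In this assay, putting 2-(cyclopentylamino)-1H-imidazol-4-yl in place of 3-amino-1H-pyrazol-4-yl on this aromatic carbon gives a 2.0-fold higher number from compound 3 to compound 4 (0.30 log units; within the scatter). Within the data shown here, this position therefore carries a group of 11 heavy atoms, with an added five-membered ring of carbon only, and the number does not move beyond the scatter; until now, the only number at this position belonged to the 6-atom 3-amino-1H-pyrazol-4-yl group of compound 3. Compound 1 stands at a limit and not at a number. The remaining step reads a number no higher from compound 1 to compound 4 (the limit leaves the size open) and no size can be given for it: the limit of > 40000 nM in this assay, at which 1 of the 4 values shown sits.

On these data alone, it remains open whether a carboxylic acid or a simple primary amine on this aromatic carbon would shift the number beyond the scatter. As far as these compounds go, it is also open whether a longer alkyl chain in place of the cyclopentyl ring on the imidazole amine would do so.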